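From tert-butyl to dimethylamino on an aromatic ring

The compounds below may be only part of what the source reports. "The series", "measured", "known", "first", "only" and "open" are said of these compounds alone.

Of the compounds shown here, two sharing one core have been measured so far, compound 1 `C=c1[nH]c(=O)/c(=C/c2ccsc2)[nH]c1=O` and compound 2 `C=c1[nH]c(=O)/c(=C/c2ccc(C(C)(C)C)cc2)[nH]c1=O`. In a functional assay on Huh7.5.1 cells (Homo sapiens) for cytotoxicity, read by MTT assay, with a stated time of 72 h (on this read-out lower numbers stand for higher toxicity in this test and higher numbers for lower toxicity in this test), compound 1 gives > 20000 nM, which is a limit of the assay and not a number. In this assay, compound 2 gives > 20000 nM, which is likewise a limit and not a number. Among the measured compounds shown here, compound 2 therefore has no exact position on the scale, and no measured step yet connects any two compounds.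

Compound 3 `C=c1[nH]c(=O)/c(=C/c2ccc(N(C)C)cc2)[nH]c1=O` is the next to be examined. It carries dimethylamino in place of tert-butyl on an aromatic carbon of a six-membered aromatic ring of carbon only, para to a large group: dimethylamino in place of tert-butyl on an aromatic carbon. The expectation for this change rests on compound 2 and on (the limit of > 20000 nM in this assay, at which 2 of the 2 values shown sit). In this assay, no change beyond the usual scatter is expected, and the reading may well remain a limit. The expected size of the step is a step that the limit leaves unreadable from compound 2 to compound 3. For compound 3 the estimated value is 22000 nM, with an expected range of 8000 nM to 60000 nM.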

Compound 3, half-maximal cytotoxic concentration: > 20000 nM
Compound 3 ended at the assay's limit (the forecaster's own chance of this, stated with the estimate: 75%); the middle value does not contradict the limit.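

The step from compound 2 to compound 3 cannot be read in this assay: both readings are limits of the assay, not numbers. The compounds shown leave open where compound 1, compound 2 and compound 3 would fall on the scale, and whether dimethylamino and tert-butyl differ at all on this read-out.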